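Aryl variation on the shared core, OVCAR-4 cell inhibition

The source may report more compounds than this note shows. Statements on the series, on what has been measured and on what is new or still open speak of the compounds shown alone.

In a functional assay on OVCAR-4 cells (Homo sapiens) for inhibition, read by sulforhodamine B assay, with a stated time of 48 h, tested at 10 uM (on this read-out lower numbers stand for less inhibition and higher numbers for more inhibition at the one concentration tested (going by the name of the read-out)), compound 1 `O=Cc1ccc(-c2cn3ccnc3c(-c3ccc4ncn(C5CCCCC5)c4c3)n2)cc1` gives 16.9%, compound 2 `c1ccc2c(-c3cn4ccnc4c(-c4ccc5ncn(C6CCCCC6)c5c4)n3)cccc2c1` gives 19.7% and compound 3 `Clc1ccc(-c2cn3ccnc3c(-c3ccc4ncn(C5CCCCC5)c4c3)n2)cc1` gives 4.57%. Compound 3 stands lowest of the three: the steps of a number 12.3 percentage points lower from compound 1 to compound 3 (beyond the scatter) and a number 15.1 percentage points lower from compound 2 to compound 3 (beyond the scatter) both run downward beyond the scatter, whereas a number 2.8 percentage points higher from compound 1 to compound 2 (within the scatter) lies within it. Compound 4 `COc1ccccc1-c1cn2ccnc2c(-c2ccc3ncn(C4CCCCC4)c3c2)n1` carries the change (2-methoxyphenyl in place of 4-chlorophenyl on an aromatic carbon). Since the steps of a number 12.3 percentage points lower from compound 1 to compound 3 (beyond the scatter) and a number 15.1 percentage points lower from compound 2 to compound 3 (beyond the scatter) into compound 3 each altered only the group at this position and lowered the read-out, a further exchange of that group is expected to move the number back up toward compound 1 and compound 2, though its size is uncertain. Compound 4 is estimated at 14% in this assay, range 2% to 28%, an expected step of a number 9.4 percentage points higher from compound 3 to compound 4 (within the scatter).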

Compound 4, a percentage reported as inhibition, at one concentration (the size of the read-out at that concentration, not a potency): 13.2%
Estimate against measurement, compound 4: 0.8 percentage points above; low and high end bracket the measured number.
By their numbers in this assay, from the lowest: compounds 3, 4, 1 and 2 (each within the scatter of the next, the first and the last beyond it).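

In this assay the exchange to 2-methoxyphenyl gives a number 8.6 percentage points higher from compound 3 to compound 4 (within the scatter) and a number 6.5 percentage points lower from compound 2 to compound 4 (within the scatter) and a number 3.7 percentage points lower from compound 1 to compound 4 (within the scatter) as its three steps, so this group cannot be told apart from any of the three earlier groups at this position. The earlier split, with 4-chlorophenyl apart from 4-formylphenyl and naphthalen-1-yl, therefore no longer reads as two separate sets of aryl groups. Nothing available gives a reason for these numbers. Open, as far as these compounds go, is whether an amine or a carboxylic acid on the phenyl ring at this position would clear the scatter against compound 2 .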